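Lactone series: stereocentre inversion from compound 2 to compound 4

A few compounds are considered here, and "the series" means these few. Any claim that something is new, unique, unknown or untested is made for them only; others in the source may bear on it.

Measured compounds in this series:
compound 1 `O=C1C=CC[C@@H](/C=C/C2CCCCC2)O1` – > 100000 nM
compound 2 `O=C1C=CC[C@@H]([C@H]2C[C@@H]2c2ccccc2)O1` – 68300 nM
compound 3 `O=C1C=CC[C@@H](/C=C/c2ccc([N+](=O)[O-])cc2)O1` – > 100000 nM

In a functional assay on MCF7 cells (Homo sapiens) for antiproliferative activity, read by luminescence and CellTiter-Glo, with a stated time of 48 h (on this read-out higher numbers stand for weaker inhibition and lower numbers for stronger inhibition), compound 1 gives > 100000 nM, which is a limit of the assay and not a number. Compound 3 likewise gives > 100000 nM, again a limit. Within the data shown here, compound 2 is the only member of the set that returns a number, 68300 nM, so it stands alone on the measured scale; no step between two numbered compounds is available for comparison.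

Compound 4 `O=C1C=CC[C@H]([C@H]2C[C@@H]2c2ccccc2)O1` has not been measured. It differs from compound 2 in the following way: the two compounds have the same atoms and bonds and differ only in configuration as drawn: 1 of 3 stereo elements differ; a stereocentre at a saturated ring carbon is drawn S in compound 2 and R in compound 4. Among the measured compounds shown here, because no measured pair in the set exhibits a change of configuration, the size of this step cannot be read from the data. The expectation is a modest loss of potency or none beyond the scatter, with the inverted centre at the lactone ring carbon more likely to weaken than to strengthen inhibition; the expected step from compound 2 to compound 4 is a 1.3-fold higher number from compound 2 to compound 4 (0.12 log units; within the scatter). Compound 4 is therefore estimated at 90000 nM in this assay, with a range from 30000 nM to 300000 nM and a real chance that only a limit is returned.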

Compound 4, half-maximal inhibitory concentration: 48200 nM
For compound 4 the middle estimate is 1.9-fold (0.27 log units) above the measured one, within the range that was stated.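

In this assay, inverting the stereocentre at the saturated ring carbon gives a 1.4-fold lower number from compound 2 to compound 4 (0.15 log units; within the scatter), so this change of configuration leaves the read-out within the scatter. Among these compounds, this is the only step between measured compounds so far, and it gives this position a size for one change, which the earlier compounds could not do. The step can be assigned to this one stereocentre alone on the strength of a single fact: the fact that compounds 2 and 4 differ only in the configuration as drawn.

The two remaining stereo elements of compounds 2 and 4 stay untested in the compounds shown, as does any replacement of the group on the shared core by an amine, a carboxylic acid or a longer chain. Comparisons that involve the other two compounds in this assay cannot be read as steps, since they offer no number to set against compounds 2 and 4: the limit of > 100000 nM in this assay, at which 2 of the 4 values shown sit.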